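This account rests on a few compounds, and the source may have more. Where it says the series, first, only, none or still open, it means among the compounds named here.

Measured compounds:
Compound 1, `O=C(C1CCCC1)N1N=CCC1c1ccccc1`: 5.4
Compound 2, `CC(C)(C)C(=O)N1N=CCC1C1CCCCC1`: 7.3
Compound 3, `Cc1nnc(N2CCC(C(=O)N3N=CC[C@H]3c3cc(F)cc(F)c3)CC2)o1`: 3.6

In a physicochemical assay for lipophilicity, read by HPLC, measured as chromatographic lipophilicity, at pH 7.4 (on this read-out lower numbers stand for lower lipophilicity and higher numbers for higher lipophilicity), compound 1 gives 5.4, the second highest of the three numbers; compound 3 stands lower and compound 2 stands higher, both gaps beyond the usual scatter. Compound 4, `O=C(c1ccccn1)N1N=CCC1c1ccccc1`, has not yet been measured. It differs from compound 1 in one place: pyridin-2-yl in place of cyclopentyl on a carbonyl carbon. The group that enters brings one hydrogen-bond acceptor where the group that leaves has none, and it is an aromatic ring in place of a non-aromatic one. Among the compounds with values here, no pair of measured compounds differs in only one place, so no measured step shows how large such a change is here. Compound 4 is expected to give 4 in this assay, within 3.3 to 4.7. The expected step of a number 1.40 log units lower from compound 1 to compound 4 (beyond the scatter) is a drop beyond the usual scatter.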

Compound 4, distribution coefficient: 2.4
For compound 4 the middle estimate is 1.60 log units above the measured one, and the stated range ends above it.
By their numbers in this assay, from the lowest: compound 4; then compound 3; then compound 1; then compound 2.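

In this assay, pyridin-2-yl in place of cyclopentyl on a carbonyl carbon gives a number 3.00 log units lower from compound 1 to compound 4 (beyond the scatter) in a single change, the first one-place step seen in this series. It shows that swapping the group at this position alone can move this read-out by a large amount, with the rest of compound 1 left untouched. As far as these compounds go, it remains open whether pyridin-4-yl or a morpholine ring at the same carbonyl carbon would give a step of similar size. Nothing on hand explains the size of this step.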